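Trifluoromethyl replaces acetamido on a weakly active compound

The compounds below may be only part of what the source reports. "The series", "measured", "known", "first", "only" and "open" are said of these compounds alone.

Compound 1 (`C=CCc1cc(-c2ccc(NC(C)=O)cc2)ccc1OC`) gives > 100000 nM in a functional assay on HUVEC cells (Homo sapiens) for antiproliferative activity, read by MTT assay, with a stated time of 24 h (a higher number here means a weaker inhibitor, a lower number a stronger inhibitor), and this is a limit of the assay, not a number. That puts compound 1 at the limit of > 100000 nM in this assay, at which 1 of the 2 values shown sits, on the scale so far. Compound 2 (`C=CCc1cc(C=O)c(OCC)c(-c2ccc(OCC)c(CC=C)c2)c1`), a differently built molecule, gives a measured 37900 nM in this assay as a true number.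

Compound 3 (`C=CCc1cc(-c2ccc(C(F)(F)F)cc2)ccc1OC`) keeps the core of compound 1 but carries trifluoromethyl in place of acetamido on an aromatic carbon. Among the measured compounds shown here, no measured pair yet shows what such a swap does, so the expectation is loose. The expected step of an at least 1.6-fold lower number from compound 1 to compound 3 (0.22 log units; that floor lies within the scatter) is a modest one toward stronger inhibition in this assay and is only an estimate. For compound 3 the estimated value is 60000 nM with an expected range from 20000 nM to 100000 nM and the assay may again report only a limit.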

Compound 3, half-maximal inhibitory concentration: > 100000 nM
Compound 3 gave a limit, no number; the forecaster's own chance of this, stated with the estimate: 50%; at least 1.6-fold (0.22 log units) between middle value and limit.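

In this assay, compound 1 and compound 3 each give only a limit, not a number, so no step can be read between them: the limit of > 100000 nM in this assay, at which 2 of the 3 values shown sit.

The compounds shown leave open whether trifluoromethyl in place of acetamido changes activity on the shared core at all.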